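Series notes: the step from compound 3 to compound 4

The source may hold more compounds than are shown below. What is called first, only, known or untested is meant among the compounds shown, and "the series" means these compounds.

For the measured compounds named here, compound 3 `C=CC(=O)Nc1cc(Nc2ncc(Cl)c(NC3CC3)n2)c(OC)cc1N1CCN(C)CC1` gives 3200 nM in a functional assay on NCI-H3122 cells (Homo sapiens) for inhibition, read by CellTiter-Glo, with a stated time of 72 h (a higher number here means a weaker inhibitor of growth, a lower number a stronger inhibitor of growth), the highest of the three numbers so far. Compound 2 `C=CC(=O)Nc1cc(Nc2ncc(Cl)c(Nc3c(F)cccc3F)n2)c(OC)cc1N1CCN(C)CC1` stands nearest, giving 2900 nM in this assay, and the step of a 1.1-fold higher number from compound 2 to compound 3 (0.04 log units; within the scatter) lies within the scatter. Compound 1 `C=CC(=O)Nc1cc(Nc2ncc(Cl)c(Nc3ccccc3S(=O)(=O)C(C)C)n2)c(OC)cc1N1CCN(C)CC1` is furthest, giving 33 nM in this assay.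

The change to compound 4 `C=CC(=O)Nc1cc(Nc2ncc(Cl)c(Nc3ccccc3S(=O)(=O)N(C)C)n2)c(OC)cc1N1CCN(C)CC1` is 2-(dimethylsulfamoyl)phenyl in place of cyclopropyl on a nitrogen on an aromatic ring. The measured steps that bear on it are a 97-fold higher number from compound 1 to compound 3 (1.99 log units; beyond the scatter) and an 88-fold higher number from compound 1 to compound 2 (1.94 log units; beyond the scatter), both large; in each the 2-(isopropylsulfonyl)phenyl group was removed and the number rose steeply. Going by the values given here, compound 4 brings back an aryl group of that type, carrying a dimethylsulfamoyl group rather than an isopropylsulfonyl group, a difference for which there is no measured precedent in this set. A large step downward in this assay is therefore expected, close to the reverse of a 97-fold higher number from compound 1 to compound 3 (1.99 log units; beyond the scatter), with some allowance for the changed sulfur substituent.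

Compound 4 is expected to give about 50 nM, with a range of 15 nM to 250 nM. The expected step is a 64-fold lower number from compound 3 to compound 4 (1.81 log units; beyond the scatter).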

Compound 4, concentration for 50% growth inhibition: 11 nM
Estimate against measurement, compound 4: 4.5-fold (0.66 log units) above; the whole stated range lies above it.
By their numbers in this assay, from the lowest: compound 4; then compound 1; then compounds 2 and 3 (each within the scatter of the next).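

In this assay the low number at this nitrogen is no longer tied to 2-(isopropylsulfonyl)phenyl: a 290-fold lower number from compound 3 to compound 4 (2.46 log units; beyond the scatter) and a 260-fold lower number from compound 2 to compound 4 (2.42 log units; beyond the scatter) show that 2-(dimethylsulfamoyl)phenyl also separates sharply from cyclopropyl and 2,6-difluorophenyl. The group on the sulfonyl sulfur also affects the result, as the modest 3.0-fold lower number from compound 1 to compound 4 (0.48 log units; beyond the scatter) lies beyond the scatter with dimethylamino in place of isopropyl. Nothing at hand explains either the large steps or the modest one.

The compounds shown leave open how a methyl or a morpholine on the sulfonyl sulfur would compare with dimethylamino and isopropyl. They also leave open whether the sulfonyl group itself is needed, which a carboxylic acid or a primary amide on the phenyl ring in its place would test.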